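Chain extension on the amine of a chloropyrimidine acid

The source may report more compounds than this note shows. Statements on the series, on what has been measured and on what is new or still open speak of the compounds shown alone.

Three compounds share a core in which a naphthyl acetic acid is tied through sulfur to a chlorinated aromatic ring that carries an amino substituent. Compound 1 `CCCCNc1cc(Cl)nc(SC(C(=O)O)c2cccc3ccccc23)n1` gives 2400 nM in an assay on isolated protein for inhibition of Polyunsaturated fatty acid 5-lipoxygenase (Homo sapiens); a higher number here means a weaker inhibitor, a lower number a stronger inhibitor. Compound 2 `O=C(O)C(Sc1nc(Cl)cc(Nc2ccc(F)cc2)n1)c1cccc2ccccc12` gives 3100 nM in this assay, and compound 3 `CC(C)CCNc1cc(Cl)nc(SC(C(=O)O)c2cccc3ccccc23)n1` gives 2500 nM. Compound 3 thus holds the second highest of the three numbers, yet all three lie within the scatter of one another: a 1.0-fold higher number from compound 1 to compound 3 (0.02 log units; within the scatter), a 1.2-fold lower number from compound 2 to compound 3 (0.09 log units; within the scatter) and a 1.3-fold higher number from compound 1 to compound 2 (0.11 log units; within the scatter).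

Compound 4 `O=C(O)C(Sc1nc(Cl)cc(NCCCc2ccccc2)n1)c1cccc2ccccc12` differs from compound 3 by benzyl in place of isopropyl on a saturated chain carbon, two bonds along the chain from a nitrogen on an aromatic ring. Among the measured compounds shown here, the steps that bear on this change are those that alter the same amine substituent: the move from butyl to 4-fluorophenyl, from butyl to isopentyl and from 4-fluorophenyl to isopentyl, none of which moved this assay beyond its scatter. Alkyl and aryl substituents alike have so far given much the same number, so the expectation is that compound 4 also shows no step beyond the scatter, with no change at the digits printed from compound 3 to compound 4 (within the scatter) expected as the change. Compound 4 is therefore estimated at 2500 nM in this assay, with a range from 1100 nM to 5500 nM.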

Compound 4, half-maximal inhibitory concentration: 1800 nM
Compound 4: middle estimate off by 1.4-fold (0.14 log units), on the high side, and the stated range covers the measured number.
By their numbers in this assay, from the lowest: compounds 4, 1, 3 and 2 (each within the scatter of the next).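

Benzyl in place of isopropyl on the saturated chain carbon, two bonds along the chain from a nitrogen on an aromatic ring, adds a six-membered aromatic ring of carbon only, and in this assay this gives a 1.4-fold lower number from compound 3 to compound 4 (0.14 log units; within the scatter) and stays within the scatter. The same holds for the other two comparisons, a 1.7-fold lower number from compound 2 to compound 4 (0.24 log units; within the scatter) and a 1.3-fold lower number from compound 1 to compound 4 (0.12 log units; within the scatter), so 3-phenylpropyl on the nitrogen now stands with butyl, isopentyl and 4-fluorophenyl, and all four compounds lie within the scatter of one another. No measurement shown here bears on this flat response to the amine substituent.

The compounds shown leave open whether an amine, a carboxylic acid or a longer chain within this substituent would give a number beyond the scatter in this assay, since only hydrocarbon chains and a 4-fluorophenyl group appear on this nitrogen. They also leave open whether a change elsewhere on the shared core, such as bromine in place of the chlorine, would shift the number more than any change to this substituent has done.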